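The source may hold more compounds than are shown below. What is called first, only, known or untested is meant among the compounds shown, and "the series" means these compounds.

Compound 1 `COC(=O)[C@@]1(C)CCC=C2[C@@H]1CC[C@@H](C)[C@]2(C)Cc1c[nH]c2ccc(C)cc12` and compound 2 `COC(=O)[C@@]1(C)CCC=C2[C@@H]1CC[C@@H](C)[C@]2(C)Cc1c[nH]c2ccc(Cl)cc12` share one core and differ only in the substituent on the six-membered aromatic ring. In a functional assay on HBL-100 cells (Homo sapiens) for inhibition, read by sulforhodamine B assay, with a stated time of 48 h (on this read-out higher numbers stand for weaker inhibition of growth and lower numbers for stronger inhibition of growth), compound 1 gives 18000 nM, and in this assay compound 2 gives 17000 nM. The step of a 1.1-fold lower number from compound 1 to compound 2 (0.02 log units; within the scatter) lies within the scatter, so compound 2 stands alongside compound 1 rather than apart from it. Compound 3 `COC(=O)[C@@]1(C)CCC=C2[C@@H]1CC[C@@H](C)[C@]2(C)Cc1c[nH]c2ccc(F)cc12` follows, with fluoro in place of chloro on an aromatic carbon. Within the data shown here, the one step that bears on this change, a 1.1-fold lower number from compound 1 to compound 2 (0.02 log units; within the scatter), was flat, so no step beyond the scatter in this assay is expected for compound 3, no change at the digits printed from compound 2 to compound 3 (within the scatter). Compound 3 is therefore estimated at 17000 nM, within 9000 nM to 34000 nM.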

Compound 3, concentration for 50% growth inhibition: 4800 nM
Compound 3: the middle estimate sits 3.5-fold (0.55 log units) above what was measured, outside the stated range (below it).
By their numbers in this assay, from the lowest: compound 3; then compounds 2 and 1 (each within the scatter of the next).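

The change to fluoro brings a 3.5-fold lower number from compound 2 to compound 3 (0.55 log units; beyond the scatter) and a 3.8-fold lower number from compound 1 to compound 3 (0.57 log units; beyond the scatter) in this assay while chloro and methyl remain within the scatter of each other. This aromatic carbon is therefore not indifferent to its substituent: fluoro separates from both other groups, though both steps are modest. No available evidence bears on why fluoro separates from chloro and methyl.

From the compounds shown here alone, whether an amine, a methoxy group or a nitrile on this carbon would fall with fluoro or with chloro and methyl remains open. Also open, going by these compounds, is whether the fluoro step persists when the methyl ester of the shared core gives way to a carboxylic acid.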